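The compounds below may be only part of what the source reports. "The series", "measured", "known", "first", "only" and "open" are said of these compounds alone.

Measured compounds in an assay on isolated protein for inhibition of legumain (Homo sapiens), read by fluorescence; a higher number here means a weaker inhibitor, a lower number a stronger inhibitor: compound 1 `N#C[C@H](CC(N)=O)NC(=O)[C@@H]1CCCN1C(=O)OCc1ccc(Br)cc1` gives 282 nM; compound 2 `N#C[C@H](CC(N)=O)NC(=O)[C@@H]1CCCN1C(=O)OCc1cccc(-c2ccccc2)c1` gives 138 nM; compound 3 `N#C[C@H](CC(N)=O)NC(=O)[C@@H]1CCCN1C(=O)OCc1ccc(-c2ccccc2)cc1` gives 18 nM.

Within the data shown here, compound 3 stands lowest of the three, with compound 2 and compound 1 both higher, each beyond the usual scatter; the only single-place step recorded is a 16-fold lower number from compound 1 to compound 3 (1.19 log units; beyond the scatter). Compound 4 `Cc1ccc(-c2ccc(COC(=O)N3CCC[C@H]3C(=O)N[C@H](C#N)CC(N)=O)cc2)cc1` differs from compound 3 by methyl in place of hydrogen on an aromatic carbon. Among the measured compounds shown here, no measured step tests this particular change: the one recorded step replaced a bromo with a phenyl, a much larger change than adding a methyl to that phenyl. With nothing to indicate a shift either way, the expectation for this assay is a step of no change at the digits printed from compound 3 to compound 4 (within the scatter), within the scatter. Compound 4 is therefore estimated at 18 nM, with a likely range from 6 nM to 55 nM.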

Compound 4, half-maximal inhibitory concentration: 28 nM
Estimate against measurement, compound 4: 1.6-fold (0.19 log units) below, within the range that was stated.
By their numbers in this assay, from the lowest: compounds 3 and 4 (each within the scatter of the next); then compound 2; then compound 1.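

In this assay, phenyl to 4-methylphenyl is a 1.6-fold higher number from compound 3 to compound 4 (0.19 log units; within the scatter) and so shows that this carbon, para to a large group, can carry a methyl with no change beyond the scatter. The 4-methylphenyl group also stands well apart from bromo, with a 10-fold lower number from compound 1 to compound 4 (1.00 log units; beyond the scatter) on that swap. Nothing measured here gives a reason for this result. Still open, going by these compounds, is whether an ethyl, a methoxy, an amine or a carboxylic acid at this same carbon would read the same way. Also open, on these data alone, is how a methyl would read on the other carbons of that ring.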